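Chlorophenyl swap from compound 2 to compound 3

The compounds below may be only part of what the source reports. "The series", "measured", "known", "first", "only" and "open" are said of these compounds alone.

Among the measured compounds shown here, in an ADME assay on L6 cells (Rattus norvegicus) for cytotoxicity, read by resazurin assay, with a stated time of 72 h (on this read-out lower numbers stand for stronger inhibition and higher numbers for weaker inhibition), compound 1 `OC(c1ccc(Cl)cc1)(c1ccc(Cl)cc1)c1cncnc1` gives 47200 nM, the only number so far. Compound 2 `Clc1ccc(C(c2cncnc2)c2ccccc2Cl)cc1` reads > 100000 nM, which is a limit of this assay and not a number.

Compound 3 `Clc1ccc(C(c2ccc(Cl)cc2)c2cncnc2)cc1` carries 4-chlorophenyl in place of 2-chlorophenyl on a saturated chain carbon bound to two aromatic carbons.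

For the measured compounds named here, no measured step is available, so the size of this change in this assay can only be estimated. A modest move toward stronger inhibition is expected, with the read-out staying in the range set by compound 1 at 47200 nM. The expected change is an at least 2.0-fold lower number from compound 2 to compound 3 (0.30 log units; that floor lies within the scatter). Compound 3 is expected at 50000 nM, with an estimated range of 20000 nM to 100000 nM.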

Compound 3, half-maximal inhibitory concentration: 70100 nM
Compound 3: the middle estimate sits 1.4-fold (0.15 log units) below what was measured; measured number inside the range.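

In this assay, 4-chlorophenyl in place of 2-chlorophenyl on a saturated chain carbon bound to two aromatic carbons gives an at least 1.4-fold lower number from compound 2 to compound 3 (0.15 log units; that floor lies within the scatter), so this change can be read only as a floor and not as a full size. Compound 2 remains a limit of the assay and not a number: the limit of > 100000 nM in this assay, at which 1 of the 3 values shown sits.

Hydrogen in place of hydroxy on a saturated chain carbon bound to three aromatic carbons gives a 1.5-fold higher number from compound 1 to compound 3 (0.17 log units; within the scatter), so this read-out does not separate hydrogen from hydroxy at that carbon.

As far as these compounds go, neither step establishes a change beyond the scatter, and the true size of the chlorophenyl swap stays unknown. From the compounds shown here alone, whether an amine or a carboxylic acid in place of hydroxy on that carbon would move the read-out beyond the scatter also remains open.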